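This account rests on a few compounds, and the source may have more. Where it says the series, first, only, none or still open, it means among the compounds named here.

Measured in a physicochemical assay for lipophilicity; a higher number here means a more lipophilic compound, a lower number a more polar compound:

- compound 1, `CCCCc1ccc2[nH]c(-c3ccc(OC)cc3)c(C3=C(Br)C(=O)NC3=O)c2c1`, gives 3.83
- compound 2, `CCCCCc1ccc2[nH]c(-c3ccc(OC)cc3)c(C3=C(Br)C(=O)NC3=O)c2c1`, gives 4.1
- compound 3, `CCCc1cccc2c(C3=C(Br)C(=O)NC3=O)c(-c3ccc(OC)cc3)[nH]c12`, gives 3.58

Compound 1 and compound 2 share one core and differ in a single place: methyl in place of hydrogen on a saturated chain carbon, four bonds along the chain from an aromatic carbon. This change gave a number 0.27 log units higher from compound 1 to compound 2 (within the scatter). Compound 3 carries another core; how it differs from compound 1 is not broken down here, and their two values lie close to each other, while the value of compound 3 lies further from that of compound 2.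

The unmeasured compound 4, `CCCCc1cccc2c(C3=C(Br)C(=O)NC3=O)c(-c3ccc(OC)cc3)[nH]c12`, is built from compound 3 by methyl in place of hydrogen on a saturated chain carbon, three bonds along the chain from an aromatic carbon. Among the measured compounds shown here, this is the same kind of change as the one from compound 1 to compound 2, not the same one: the new methyl sits three bonds along the chain from an aromatic carbon, where in compound 2 it sits four bonds along the chain from an aromatic carbon. Because the earlier change gave a number 0.27 log units higher from compound 1 to compound 2 (within the scatter), a step of about the same size is expected here, a number 0.30 log units higher from compound 3 to compound 4 (within the scatter). Compound 4 is therefore estimated at 3.88 in this assay, between 3.6 and 4.15.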

Compound 4, partition coefficient: 3.81
Beside the measured number, compound 4's estimate is 0.07 log units above it, within the range that was stated.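

In this assay, adding the methyl on the core of compound 3 gave a number 0.23 log units higher from compound 3 to compound 4 (within the scatter), and on the core of compound 1 the same kind of change, placed four bonds along the chain from an aromatic carbon rather than three, gave a number 0.27 log units higher from compound 1 to compound 2 (within the scatter), so the two cores read alike for this change. Each step stays within the scatter, however, so neither pair alone establishes a real shift, and a single pair on each of two cores, with the methyl at different places along the chain, gives no rule for the whole series. Nothing available accounts for this result.

Open, as far as these compounds go, is how this assay would read on either core with an amine or a carboxylic acid in place of the chain. Also open, from the compounds shown here alone, is whether a longer chain on the core of compound 3 would continue with steps of this size, and whether they would add up to more than the scatter.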